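Methyl in place of fluoro: compound 2 to compound 4

The compounds below may be only part of what the source reports. "The series", "measured", "known", "first", "only" and "open" are said of these compounds alone.

Three analogues have been run in a functional assay on P388 cells (Mus musculus) for inhibition; on this read-out lower numbers stand for stronger inhibition and higher numbers for weaker inhibition. Compound 1 `O=C1/C(=C/c2ccc(Cl)cc2Cl)CCCc2ccccc21` gives 14000 nM, compound 3 `O=C1/C(=C/c2ccccc2[N+](=O)[O-])CCc2ccccc21` gives 12600 nM, and compound 2 `O=C1/C(=C/c2ccccc2F)Cc2ccccc21` gives 31700 nM, the highest number of the three, with both gaps lying beyond the scatter. Compound 4 `Cc1ccccc1/C=C1\Cc2ccccc2C1=O` has not yet been measured in this assay. It differs from compound 2 by methyl in place of fluoro on an aromatic carbon. Among the compounds with values here, no measured pair in this set isolates this exchange, so no reference step is available. For compound 4 the step of a 1.1-fold lower number from compound 2 to compound 4 (0.05 log units; within the scatter) is expected to be small, at most a modest shift, and the direction is open. Compound 4 is estimated at 28000 nM, with a plausible range from 9000 nM to 90000 nM.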

Compound 4, half-maximal inhibitory concentration: 23900 nM
Compound 4: middle estimate off by 1.2-fold (0.07 log units), on the high side; measured number inside the range.
By their numbers in this assay, from the lowest: compounds 3, 1, 4 and 2 (each within the scatter of the next, the first and the last beyond it).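

In this assay, within the data shown here, the first isolated exchange at this position, on an aromatic carbon ortho to a large group, gives a 1.3-fold lower number from compound 2 to compound 4 (0.12 log units; within the scatter). Fluoro and methyl are therefore not distinguished here on the core of compound 2. Nothing available accounts for this likeness between the two groups.
From the compounds shown here alone, whether an amine, a hydroxyl or a carboxylic acid at this position would shift the number beyond the scatter remains open. So does whether the same exchange reads alike on the cores of compound 1 and compound 3.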